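Taking the carboxy group off compound 1

The compounds below may be only part of what the source reports. "The series", "measured", "known", "first", "only" and "open" are said of these compounds alone.

Going by the values given here, in a physicochemical assay for solubility, read by spectrophotometry, in phosphate buffer, measured as kinetic solubility, with a stated time of 18 h, at pH 7.4 (a lower number here means a less soluble compound, a higher number a more soluble compound), compound 1 (`O=C(O)COc1cc(Cl)c(C(=O)Nc2cccc(-c3nc4ccccc4s3)c2)cc1[N+](=O)[O-]`) gives 6700 nM and stands highest of the three compounds measured so far. Compound 2 (`Cc1cc(NC(=O)c2cc([N+](=O)[O-])ccc2Cl)cc(-c2nc3ccccc3o2)c1O`) is the nearest at 90 nM and compound 3 (`O=C(Nc1ccc(O)c(-c2nc3ccccc3s2)c1)c1cc([N+](=O)[O-])ccc1Cl`) the furthest at 23 nM with both gaps to compound 1 beyond the scatter. Among the compounds with values here, no measured pair differs in one place only, so the series offers no direct precedent for the change at hand.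

Compound 4 (`COc1cc(Cl)c(C(=O)Nc2cccc(-c3nc4ccccc4s3)c2)cc1[N+](=O)[O-]`), not yet measured, carries hydrogen in place of carboxy on a saturated chain carbon bound to an oxygen on an aromatic ring, which turns carboxymethoxy into methoxy. Compound 4 would share the absence of a carboxy group with compound 2 (90 nM) and compound 3 (23 nM) while compound 1 (6700 nM) alone carries one. This is a thin basis, as those two compounds also differ from compound 1 elsewhere in the structure. A downward move beyond the scatter is nevertheless expected, and the estimated size of the step of a 34-fold lower number from compound 1 to compound 4 (1.53 log units; beyond the scatter) is large. In this assay the estimate for compound 4 is 200 nM with 30 nM to 1200 nM as the expected range.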

Compound 4, solubility: 10 nM
Estimate against measurement, compound 4: 20-fold (1.30 log units) above; the whole stated range lies above it.
By their numbers in this assay, from the lowest: compound 4; then compound 3; then compound 2; then compound 1.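

Carboxymethoxy to methoxy is the first change in this series that can be read in one place alone, and in this assay it gives a 670-fold lower number from compound 1 to compound 4 (2.83 log units; beyond the scatter). The earlier compounds shown here differed from compound 1 in several places, so they could not tie its high number to the carboxy group; this pair ties that number to this one position on the shared core, with no other structural difference left to share the step. Nothing at hand gives a measured reason for a step of this size.

Still open, on these data alone, is whether the step belongs to the carboxy group itself, or whether another group at this saturated chain carbon, such as an amine or a longer chain ending in a carboxylic acid, would give a number of similar size. Also open, as far as these compounds go, is whether the same change would give a step of similar size on a different core, since this single pair speaks only for the core of compound 1.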